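The compounds below may be only part of what the source reports. "The series", "measured", "known", "first", "only" and "open" are said of these compounds alone.

Measured so far in a functional assay on SK-HEP1 cells (Homo sapiens) for antiproliferative activity; on this read-out lower numbers stand for stronger inhibition of growth and higher numbers for weaker inhibition of growth:
Compound 1, `O=c1cc(-c2ccccc2)oc2ccc(OC/C(=N/O)c3ccccc3)cc12`, gives 700000 nM.
Compound 2, `O=c1cc(-c2ccccc2)oc2ccc(OC/C(=N/O)c3ccc(F)cc3)cc12`, gives 2800000 nM.
Compound 3, `CO/N=C(/COc1ccc2c(=O)c(-c3ccccc3)coc2c1)c1ccccc1`, gives 7400000 nM.

Compound 4, `CO/N=C(/COc1ccc2c(=O)c(-c3ccccc3)coc2c1)c1ccc(F)cc1`, has not yet been measured in this assay. It differs from compound 3 in one place: fluoro in place of hydrogen on an aromatic carbon. The same change separates compound 1 from compound 2, (fluoro in place of hydrogen on an aromatic carbon), and there it made a 4.0-fold higher number from compound 1 to compound 2 (0.60 log units; beyond the scatter). The difference between the core of compound 1 and the core of compound 3 is not broken down here; what the numbers show is that compound 3 gives the highest of the three values, with its steps to compound 2 and to compound 1 both beyond the scatter. Since the place of the change is described in the same words for both pairs, on an aromatic carbon of a six-membered aromatic ring of carbon only, para to a large group, a step of similar size is expected from compound 3 to compound 4, a 3.4-fold higher number from compound 3 to compound 4 (0.53 log units; beyond the scatter), resting on a 4.0-fold higher number from compound 1 to compound 2 (0.60 log units; beyond the scatter). Compound 4 is therefore expected to give about 25000000 nM in this assay, most likely between 8000000 nM and 80000000 nM.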

Compound 4, concentration for 50% growth inhibition: 6100000 nM
Compound 4: the middle estimate sits 4.1-fold (0.61 log units) above what was measured, and the stated range ends above it.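

In this assay, for the compounds shown here, fluoro in place of hydrogen on an aromatic carbon gave a 1.2-fold lower number from compound 3 to compound 4 (0.08 log units; within the scatter), so on this core the change from phenyl to 4-fluorophenyl leaves no step that stands out from repeat measurement. Set beside the step on the core of compound 1, this result shows that the size of the step did not carry over from one core to the other: the same change on two cores in this assay, a 4.0-fold higher number (0.60 log units; beyond the scatter) from compound 1 to compound 2 and a 1.2-fold lower number (0.08 log units; within the scatter) from compound 3 to compound 4, 4.9-fold (0.69 log units) apart, beyond the scatter of two such steps. Going by these compounds alone, it does not show what makes the two steps part, since there is only one pair on each core and compound 1 and compound 3 differ in more than one place.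

The compounds shown leave open whether a chloro or a methoxy group in the same place would also give different steps on the two cores. They also leave open whether fluoro in place of hydrogen would follow either step on a third core.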